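The compounds below may be only part of what the source reports. "The series", "measured", "known", "first", "only" and "open" are said of these compounds alone.

Compound 1 `Nc1nc(-c2ccc(C(F)F)o2)nc2sc(Cc3ccccc3)cc12` in a functional assay on CHO-K1 cells for antagonist activity at adenosine receptor A1 (Homo sapiens), read by a beta-galactosidase reporter and cAMP accumulation, with stated times of 15 min and 6 h (on this read-out higher numbers stand for weaker inhibition and lower numbers for stronger inhibition), gives 3000 nM, the highest of the two numbers shown. Its nearest neighbour is compound 2 `COc1ccccc1Cc1cc2c(N)nc(-c3ccc(C(F)F)o3)nc2s1`, at 516 nM; the step of a 5.8-fold lower number from compound 1 to compound 2 (0.76 log units; beyond the scatter) is the only measured one in the set. Compound 3 `Cc1csc(-c2nc(N)c3cc(C4(c5ccccc5)CC4)sc3n2)n1` returns only a limit, > 610 nM, not a number (the limit of > 610 nM in this assay, at which 1 of the 3 values shown sits).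

Compound 4 `COc1cccc(-c2nc(N)c3cc(Cc4ccccc4)sc3n2)c1` differs from compound 1 by 3-methoxyphenyl in place of 5-(difluoromethyl)furan-2-yl on an aromatic carbon. Among the measured compounds shown here, no measured step concerns this part of the core; the single step, from hydrogen to methoxy on the benzyl ring, gives no direct guide. The expectation for compound 4 is therefore a change no larger than the scatter, no change at the digits printed from compound 1 to compound 4 (within the scatter), with the estimate placed at 3000 nM and a range from 900 nM to 10000 nM.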

Compound 4, inhibition constant: 266 nM
For compound 4 the middle estimate is 11-fold (1.05 log units) above the measured one, and the stated range ends above it.
By their numbers in this assay, from the lowest: compounds 4 and 2 (each within the scatter of the next); then compound 1.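

In this assay the group on this aromatic carbon between two ring nitrogen atoms clearly counts: 3-methoxyphenyl in place of 5-(difluoromethyl)furan-2-yl gives an 11-fold lower number from compound 1 to compound 4 (1.05 log units; beyond the scatter) with the benzyl group unchanged. Among the compounds shown here, the earlier measured step concerned only the benzyl ring, so this is the first measured change here, and it comes with equal counts of heavy atoms and hydrogen-bond acceptors on both groups. Nothing given bears on the cause of this step.

Still open, from the compounds shown here alone, is how a morpholine or a simple amine at this position would read. Also open, going by these compounds, is whether methoxy on the benzyl ring adds anything when 3-methoxyphenyl is present.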